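Phenyl to cyclopropyl on the ring amide nitrogen

The source may report more compounds than this note shows. Statements on the series, on what has been measured and on what is new or still open speak of the compounds shown alone.

Measured compounds:
compound 1 `COc1ncc(-c2ccc3c(c2)N(c2ccccc2)C(=O)CO3)cc1NS(=O)(=O)c1ccc(F)cc1` — in a functional assay on A549 cells (Homo sapiens) for antiproliferative activity, read by MTT assay, with a stated time of 72 h (on this read-out lower numbers stand for stronger inhibition and higher numbers for weaker inhibition), compound 1 gives 3490 nM.
compound 3 `COc1ncc(-c2ccc3c(c2)N(C2CC2)C(=O)CO3)cc1NS(=O)(=O)c1ccc(F)cc1` — in this assay compound 3 gives 3320 nM.
compound 2 `O=C1COc2ccc(-c3cccc(NS(=O)(=O)c4ccc(F)cc4)c3)cc2N1c1ccccc1` — in this assay compound 2 reaches only > 40000 nM, which is a limit of the assay and not a number.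

The change from compound 1 to compound 3 is cyclopropyl in place of phenyl on an amide-type nitrogen in a ring; it gives a 1.1-fold lower number from compound 1 to compound 3 (0.02 log units; within the scatter). The same change leads from compound 2 to compound 4 `O=C1COc2ccc(-c3cccc(NS(=O)(=O)c4ccc(F)cc4)c3)cc2N1C1CC1`, namely (cyclopropyl in place of phenyl on an amide-type nitrogen in a ring). The difference between the two cores of compound 1 and compound 2 is not broken down here. Compound 2 stands at the limit of > 40000 nM in this assay, at which 1 of the 3 values shown sits. Because the measured step is a 1.1-fold lower number from compound 1 to compound 3 (0.02 log units; within the scatter), the step expected here is also small, a step that the limit leaves unreadable from compound 2 to compound 4. Compound 4 is therefore estimated at 50000 nM in this assay, between 20000 nM and 150000 nM, and most likely reported again only as a limit.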

Compound 4, half-maximal inhibitory concentration: > 40000 nM
Compound 4 gave a limit, no number (the forecaster's own chance of this, stated with the estimate: 80%); the middle value does not contradict the limit.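

No step can be read from compound 2 to compound 4, since both compounds give only a limit and no number: the limit of > 40000 nM in this assay, at which 2 of the 4 values shown sit. The compounds shown leave open whether cyclopropyl in place of phenyl changes activity at all on the core of compound 2.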